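Changing the ring group on the carbonyl of compound 1

The source may report more compounds than this note shows. Statements on the series, on what has been measured and on what is new or still open speak of the compounds shown alone.

In a functional assay on A2780 cells (Homo sapiens) for inhibition, read by sulforhodamine B assay, with a stated time of 72 h (on this read-out lower numbers stand for stronger inhibition and higher numbers for weaker inhibition), compound 1 (`O=C(NCc1ccc(S(=O)(=O)N2CCCCC2)cc1)c1cc2cnccc2s1`) gives 1600 nM and so stands toward the weak end of the small measured set. Compound 3 (`O=C(NCc1ccc(S(=O)(=O)c2ccccc2)cc1)c1c[nH]c2ccncc12`) gives 2100 nM which lies within the scatter of that number, while compound 2 (`O=C(NCc1ccc(S(=O)(=O)c2cccc(C(F)(F)F)c2)cc1)c1cc2cnccc2[nH]1`) gives 3 nM and lies far lower.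

Compound 4 (`O=C(NCc1ccc(S(=O)(=O)N2CCCCC2)cc1)c1ccn2cncc2c1`) keeps the rest of compound 1 and alters only the group on the carbonyl carbon: a group of 9 heavy atoms (7 carbon, 2 nitrogen; one five-membered aromatic ring with 2 hetero atoms, one six-membered aromatic ring with 1 hetero atom) in place of a group of 9 heavy atoms (7 carbon, 1 nitrogen, 1 sulfur; one five-membered aromatic ring with 1 hetero atom, one six-membered aromatic ring with 1 hetero atom), on a carbonyl carbon. Among the measured compounds shown here, no measured pair differs in one place, so the data give no direct size for such a change. The wide span between compound 3 at 2100 nM and compound 2 at 3 nM leaves room for a sizeable move, though it cannot be assigned to this group alone. A moderate step toward lower numbers in this assay is therefore expected, beyond the scatter but well short of reaching compound 2. The estimated change is a 5.3-fold lower number from compound 1 to compound 4 (0.73 log units; beyond the scatter) overall. For compound 4 the estimated value is 300 nM and the expected range runs from 30 nM to 2500 nM on this read-out.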

Compound 4, half-maximal inhibitory concentration: > 10000 nM
Compound 4: no number, only a limit; the forecaster's own chance of this, stated with the estimate: 8%; middle value at least 33-fold (1.52 log units) away from the limit.
By their numbers in this assay, from the lowest: compound 2; then compounds 1 and 3 (each within the scatter of the next). At a limit, above all of these: compound 4.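

In this assay compound 4 gives > 10000 nM, which is a limit of the assay and not a number. The group on the carbonyl carbon therefore matters for the activity of compound 1: although the exchange leaves the heavy-atom count, the hydrogen-bond donor and acceptor counts and the absence of net charge unchanged, it produces an at least 6.2-fold higher number from compound 1 to compound 4 (0.79 log units; beyond the scatter). That step sets only a lower bound on the size of the change, because the value for compound 4 is a limit: the limit of > 10000 nM in this assay, at which 1 of the 4 values shown sits.

The compounds shown do not reveal which feature of the entering group accounts for the loss, nor how a single pyridine ring on the carbonyl carbon would compare. They also leave open whether the same exchange would have a similar effect with a different group on the sulfonyl.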